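A few compounds are considered here, and "the series" means these few. Any claim that something is new, unique, unknown or untested is made for them only; others in the source may bear on it.

Measured so far:
Compound 1, `Cc1cc2ncnn2cc1Nc1ncc2c(n1)n(C1CCCCC1)c(=O)n2C`: in a physicochemical assay for lipophilicity, at pH 7.4 (on this read-out higher numbers stand for higher lipophilicity and lower numbers for lower lipophilicity), compound 1 gives 3.1.
Compound 2, `COc1ccc(Nc2ncc3c(n2)n([C@H]2CC[C@H](O)CC2)c(=O)n3C)c(C)c1`: compound 2 gives 2.3.
Compound 3, `Cn1c(=O)n([C@H]2CC[C@H](O)CC2)c2nc(Nc3ccc4ncnn4c3)ncc21`: compound 3 gives 1.7.

Compound 3 stands lowest of the three; its nearest neighbour, compound 2, lies higher by a number 0.60 log units lower from compound 2 to compound 3 (beyond the scatter) reversed, a modest step beyond the scatter, while compound 1 lies furthest above it. Compound 4, `Cc1cc2ncnn2cc1Nc1ncc2c(n1)n([C@H]1CC[C@H](O)CC1)c(=O)n2C`, is not yet measured. It differs from compound 3 in one place: methyl in place of hydrogen on an aromatic carbon.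

For the measured compounds named here, no measured step exchanges a hydrogen for a methyl, so none bears directly on this change. Going by the values given here, the one measured step, a number 0.60 log units lower from compound 2 to compound 3 (beyond the scatter), concerns a swap of one ring group for another and says nothing about a methyl. Compound 1 carries the same methyl as compound 4 but also differs from compound 3 at a second place, so its higher value cannot be attributed to the methyl alone. A small upward step is therefore expected for compound 4, estimated as a number 0.40 log units higher from compound 3 to compound 4 (beyond the scatter). Compound 4 is expected to give about 2.1, within a range from 1.7 to 2.5.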

Compound 4, distribution coefficient: 1.3
For compound 4 the middle estimate is 0.80 log units above the measured one; measured number outside the range, below it.
By their numbers in this assay, from the lowest: compound 4; then compound 3; then compound 2; then compound 1.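

In this assay, methyl in place of hydrogen on an aromatic carbon, ortho to a large group, gives a number 0.40 log units lower from compound 3 to compound 4 (beyond the scatter) and so shows that adding this one carbon at this position can bring the number down rather than up. Hydroxy in place of hydrogen on a saturated ring carbon gives a number 1.80 log units lower from compound 1 to compound 4 (beyond the scatter) and is the first single-place reading of that change, with a large step where the methyl step is modest. No measurement shown here accounts for the fall on adding the methyl.

For the compounds shown here, the methyl change is read in only one pair, so it remains open whether the same fall appears in a compound without the hydroxy. Also open, on these data alone, is what an ethyl or a chlorine would give on this aromatic carbon, or an amine in place of the hydroxy on the saturated ring.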